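The compounds below may be only part of what the source reports. "The series", "measured", "known", "first", "only" and "open" are said of these compounds alone.

In a functional assay on B16-F10 cells (Mus musculus) for antiproliferative activity, read by CCK-8 assay, with a stated time of 48 h (on this read-out higher numbers stand for weaker inhibition and lower numbers for stronger inhibition), compound 1 `COc1ccc(/C=C\c2cc(OC)c(OC)c(OC)c2)cc1OCc1ccc(CN2C[C@H](O)C[C@@H]2C(=O)O)cc1` gives > 10000 nM, which is a limit of the assay. Compound 2 `COc1ccc(/C=C\c2cc(OC)c(OC)c(OC)c2)cc1OCc1ccc(CN[C@H](C(=O)O)[C@H](C)O)cc1` gives > 10000 nM, also a limit, and so stands at the limit of > 10000 nM in this assay, at which 2 of the 3 values shown sit. Compound 3 `COc1ccc(/C=C\c2cc(OC)c(OC)c(OC)c2)cc1OCc1ccc(CN2CCCCC2C(=O)NCCNC(=O)OC(C)(C)C)cc1` gives a true number, 4700 nM. Compound 4 `COc1ccc(/C=C\c2cc(OC)c(OC)c(OC)c2)cc1OCc1ccc(CNCCNC(C)=O)cc1` differs from compound 2 by one change: 2-acetamidoethyl in place of 1-carboxy-2-hydroxypropyl on an amine nitrogen. This places 2-acetamidoethyl in place of 1-carboxy-2-hydroxypropyl on an amine nitrogen. For the measured compounds named here, the one measured step, a step that the two limits leave unreadable from compound 1 to compound 2, gives no size to carry over. The better guide is compound 3, which has no carboxy group and reads 4700 nM. In this assay, a step of an at least 2.5-fold lower number from compound 2 to compound 4 (0.39 log units; beyond the scatter) towards stronger inhibition is therefore expected, though its size is uncertain. For compound 4 the estimated value is 4000 nM, with an expected range of 1000 nM to 10000 nM.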

Compound 4, half-maximal inhibitory concentration: 2500 nM
The estimate for compound 4 lay 1.6-fold (0.20 log units) above the measured number, and the stated range covers the measured number.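

In this assay, for the compounds shown here, 2-acetamidoethyl in place of 1-carboxy-2-hydroxypropyl on the amine nitrogen gives the first readable step at this position, an at least 4.0-fold lower number from compound 2 to compound 4 (0.60 log units; beyond the scatter). Set against 2-carboxy-4-hydroxypyrrolidin-1-yl, the same amine side chain gives an at least 4.0-fold lower number from compound 1 to compound 4 (0.60 log units; beyond the scatter). The value of compound 2 is a limit of the assay, not a number: the limit of > 10000 nM in this assay, at which 2 of the 4 values shown sit.

The compounds shown leave open whether the lower number goes with the loss of the carboxylic acid or with the entry of the acetamide. They also leave open how a free primary amine or a longer chain would read here.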